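The compounds below may be only part of what the source reports. "The series", "measured", "known", "first", "only" and "open" are said of these compounds alone.

In a functional assay on a cell-free system (plasma, Oryctolagus cuniculus) for inhibition, with stated times of 5 min, 1 min and 6 min (a higher number here means a weaker inhibitor, a lower number a stronger inhibitor), compound 1 (`CCOC(=O)c1[nH]c(-c2cccc(C#N)c2)nc1C`) reads > 30000 nM and this is a limit of the assay rather than a number. With 2-ethoxyethoxy in place of hydrogen on an aromatic nitrogen, compound 2 (`CCOCCOn1c(-c2cccc(C#N)c2)nc(C)c1C(=O)OCC`) gives 6250 nM here, which means an at least 4.8-fold lower number from compound 1 to compound 2 (0.68 log units; beyond the scatter) for that change. With (4-chlorobenzyl)oxy on the same nitrogen, compound 3 (`CCOC(=O)c1c(C)nc(-c2cccc(C#N)c2)n1OCc1ccc(Cl)cc1`) gives 6830 nM here, which means an at least 4.3-fold lower number from compound 1 to compound 3 (0.64 log units; beyond the scatter) for that change. For the measured compounds named here, compound 3 therefore stands level with compound 2, the only other measured number, and the two cannot be told apart.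

Compound 4 (`CCOC(=O)c1c(C)nc(-c2cccc(C#N)c2)n1OCc1ccc(C)cc1`) differs from compound 3 in one group, with methyl in place of chloro on an aromatic carbon as the whole change: methyl in place of chloro on an aromatic carbon, which turns (4-chlorobenzyl)oxy into (4-methylbenzyl)oxy. Going by the values given here, no measured step makes this swap on its own. The larger steps from compound 1 concern the hydrogen on the nitrogen, which is not at stake here. The nearest guide is a 1.1-fold higher number from compound 2 to compound 3 (0.04 log units; within the scatter) for 4-chlorophenyl in place of ethoxymethyl, a bigger swap at the same end of the molecule that stays within the scatter. In this assay no step beyond the scatter is therefore expected, and the estimated change is a 1.0-fold higher number from compound 3 to compound 4 (0.01 log units; within the scatter) for this swap. The estimate for compound 4 is 7000 nM with an expected range from 3000 nM to 16000 nM in this measurement.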

Compound 4, half-maximal inhibitory concentration: 6310 nM
Compound 4: middle estimate off by 1.1-fold (0.05 log units), on the high side; low and high end bracket the measured number.
By their numbers in this assay, from the lowest: compounds 2, 4 and 3 (each within the scatter of the next). At a limit, above all of these: compound 1.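

In this assay, methyl in place of chloro on an aromatic carbon, para to a large group, is the only step shown at this position, and it gives a 1.1-fold lower number from compound 3 to compound 4 (0.03 log units; within the scatter), so this swap of one heavy atom for another does not separate the two compounds. The (4-methylbenzyl)oxy group also reads level with the 2-ethoxyethoxy chain, with a 1.0-fold higher number from compound 2 to compound 4 (0.00 log units; within the scatter), so a benzyl-type group with either substituent and an open chain now sit together on the aromatic nitrogen in compound 2, compound 3 and compound 4. Compound 4 also stands clear of the parent that carries hydrogen on that nitrogen, with an at least 4.7-fold lower number from compound 1 to compound 4 (0.67 log units; beyond the scatter), a step whose true size stays unknown as it is set by the limit for compound 1: the limit of > 30000 nM in this assay, at which 1 of the 4 values shown sits.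

Chloro and methyl are both single heavy atoms, so it remains open how a bigger or very different group at this place on the ring would read, such as methoxy, an amine or a carboxylic acid. From the compounds shown here alone, it is also open whether any group on the nitrogen, for example a longer chain ending in an amine, would move the number clearly away from these three compounds.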